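The source may report more compounds than this note shows. Statements on the series, on what has been measured and on what is new or still open speak of the compounds shown alone.

Measured so far in an assay on isolated protein (Mus musculus) for inhibition of IL15-IL15 receptor (Homo sapiens), read by resazurin assay, with stated times of 30 min and 2.5 days; a lower number here means a stronger inhibitor, a higher number a weaker inhibitor:
Compound 1 `Cn1c(Cc2nn(C)c(=O)c3ccccc23)nnc1SCCCCCCCC(=O)Nc1ccc(O)cc1`: > 30000 nM, which is a limit of the assay.
Compound 2 `Cn1c(Cc2nn(C)c(=O)c3ccccc23)nnc1SCCCCCCCC(=O)Nc1ccc(Cl)cc1Cl`: 1900 nM.
Compound 3 `Cn1c(Cc2nn(C)c(=O)c3ccccc23)nnc1SCC(=O)Nc1ccc(F)cc1F`: "not active" (no number reported).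

Among the compounds with values here, compound 2 therefore holds the only definite number; compound 1 sits at a limit, and compound 3 has no number at all. Within the data shown here, the single measured step, an at least 15-fold lower number from compound 1 to compound 2 (1.19 log units; beyond the scatter), changes only the aryl group on the amide nitrogen. Compound 4 `Cn1c(Cc2nn(C)c(=O)c3ccccc23)nnc1SCCCCCCCC(=O)Oc1ccc(Cl)cc1Cl` keeps the 2,4-dichlorophenyl of compound 2 but alters the link to it: 2,4-dichlorophenoxy in place of (2,4-dichlorophenyl)amino on a carbonyl carbon. Among the measured compounds shown here, no measured step touches this link, so the step from compound 1 to compound 2 gives no direct guide. The amide hydrogen is lost, an untested change, and compound 4 is expected to come out weaker in this assay, by roughly a 2.6-fold higher number from compound 2 to compound 4 (0.42 log units; beyond the scatter). The estimate for compound 4 is 5000 nM, spanning 1500 nM to 30000 nM.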

Compound 4, half-maximal inhibitory concentration: 800 nM
The estimate for compound 4 lay 6.3-fold (0.80 log units) above the measured number, outside the stated range (below it).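

In this assay, the amide hydrogen proves dispensable in this series: 2,4-dichlorophenoxy in place of (2,4-dichlorophenyl)amino on the carbonyl carbon gives a 2.4-fold lower number from compound 2 to compound 4 (0.38 log units; beyond the scatter). Set against the 4-hydroxyphenyl amide, the change gives an at least 37-fold lower number from compound 1 to compound 4 (1.57 log units; beyond the scatter). That second step is only a bound, as compound 1 stands at a limit of the assay: the limit of > 30000 nM in this assay, at which 1 of the 4 values shown sits.

Still open, going by these compounds, is whether the gain comes from the oxygen itself or simply from losing the amide hydrogen, which a methylated amide nitrogen or a ketone at this place could separate. A free carboxylic acid in place of the 2,4-dichlorophenoxy group would show whether the aryl group is needed at all.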